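This account rests on a few compounds, and the source may have more. Where it says the series, first, only, none or still open, it means among the compounds named here.

Working notes on the series. Compound 1 `COc1ccc(C2OC(c3cc(OC)c(OC)c(OC)c3)=NN2C(C)=O)c(OC)c1`, compound 2 `COc1cc(C(=O)N/N=C/c2c(Cl)cccc2Cl)cc(OC)c1OC` and compound 3 `COc1cc(C(=O)N/N=C/c2ccc(Cl)c([N+](=O)[O-])c2)cc(OC)c1OC` have been run in a functional assay on BGC-823 cells (Homo sapiens) for antiproliferative activity, read by MTT assay, tested at 1 uM; on this read-out higher numbers stand for a stronger effect at the one concentration tested and lower numbers for a weaker effect. Compound 1 gives 6.3%, compound 2 gives 0.9% and compound 3 gives -5.8%. Compound 1 stands highest of the three numbers; its gap to compound 2 lies within the scatter, its gap to compound 3 beyond it. Compound 4 `COc1cc(C2=NN(C(C)=O)C(c3ccc(Cl)c([N+](=O)[O-])c3)O2)cc(OC)c1OC` is not yet measured. It differs from compound 1 in one place: 4-chloro-3-nitrophenyl in place of 2,4-dimethoxyphenyl on a saturated ring carbon. No change between measured compounds matches this one, so the expectation rests on the values alone. The step of a number 6.3 percentage points lower from compound 1 to compound 4 (within the scatter) is expected to be small and downward, within the scatter, because compound 3 gives -5.8%. Compound 4 is estimated at 0%, with a range from -10% to 10%.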

Compound 4, a percentage reported as inhibition, at one concentration (the size of the read-out at that concentration, not a potency): -2.3%
Compound 4: the middle estimate sits 2.3 percentage points above what was measured, and the stated range covers the measured number.
By their numbers in this assay, from the lowest: compounds 3, 4, 2 and 1 (each within the scatter of the next, the first and the last beyond it).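

On the saturated ring carbon of the shared core, 4-chloro-3-nitrophenyl in place of 2,4-dimethoxyphenyl gives a number 8.6 percentage points lower from compound 1 to compound 4 (within the scatter) in this assay at the one concentration tested. Among the compounds shown here, this is the first single-place step, and it does not separate the two groups at this position. Nothing on hand gives a reason for the step.

Still open, as far as these compounds go, is whether a pyridine ring or a benzoic acid on this carbon, or a propanoyl group in place of the acetyl group, would move the read-out beyond the scatter.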